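The source may hold more compounds than are shown below. What is called first, only, known or untested is meant among the compounds shown, and "the series" means these compounds.

Three close relatives of one core have been tested in a functional assay on MCF7 cells (Homo sapiens) for cytotoxicity, read by MTT assay, with a stated time of 72 h; on this read-out higher numbers stand for weaker inhibition and lower numbers for stronger inhibition. Compound 1 `Cc1cccc(CSc2cc(Cl)c(C)cc2S(=O)(=O)/N=C(\N)n2nccc2-c2ccccc2)c1` gives 47000 nM, compound 2 `Cc1ccc(CSc2cc(Cl)c(C)cc2S(=O)(=O)/N=C(\N)n2nc(C)cc2-c2ccccc2)cc1` gives 89000 nM, and compound 3 `Cc1cc(-c2ccccc2)n(/C(N)=N/S(=O)(=O)c2cc(C)c(Cl)cc2SCc2cccc(C(F)(F)F)c2)n1` gives 41000 nM, the lowest of the three numbers, although compound 1 sits within the scatter of it. Within the data shown here, the only recorded single step is a 2.2-fold lower number from compound 2 to compound 3 (0.34 log units; beyond the scatter). Compound 4 `Cc1cccc(CSc2cc(Cl)c(C)cc2S(=O)(=O)/N=C(\N)n2nc(C)cc2-c2ccccc2)c1` differs from compound 3 by methyl in place of trifluoromethyl on an aromatic carbon, which partly reverses that step while keeping the 3-methylbenzyl group that compound 1 also carries. Since the comparison undoes part of the change that produced a 2.2-fold lower number from compound 2 to compound 3 (0.34 log units; beyond the scatter), the expected step is a 1.5-fold higher number from compound 3 to compound 4 (0.17 log units; within the scatter), staying within the scatter. The estimate for compound 4 is 60000 nM, between 30000 nM and 120000 nM.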

Compound 4, half-maximal inhibitory concentration: 105000 nM
For compound 4 the middle estimate is 1.8-fold (0.24 log units) below the measured one; low and high end bracket the measured number.
By their numbers in this assay, from the lowest: compounds 3, 1, 2 and 4 (each within the scatter of the next, the first and the last beyond it).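

Among these compounds, putting methyl in place of trifluoromethyl gives a 2.6-fold higher number from compound 3 to compound 4 (0.41 log units; beyond the scatter) in this assay and so shows, in a direct pair the earlier compounds lacked, that the number responds to the group at this position. By contrast, 3-methylphenyl in place of 4-methylphenyl gives a 1.2-fold higher number from compound 2 to compound 4 (0.07 log units; within the scatter) and so no readable change. Methyl in place of hydrogen on an aromatic carbon elsewhere in the core gives a 2.2-fold higher number from compound 1 to compound 4 (0.35 log units; beyond the scatter) and so that site responds as well.

No available data explain these shifts. Going by these compounds, whether a nitrile or an amine in place of trifluoromethyl would give a lower number than compound 3 remains open.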